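This account rests on a few compounds, and the source may have more. Where it says the series, first, only, none or still open, it means among the compounds named here.

Compound 1 `CCCSc1nc(NC2CCCCC2)c2ncn([C@@H]3O[C@H](CO)[C@@H](O)[C@H]3O)c2n1` gives 151000 nM
Compound 2 `CCCSc1nc(NCc2ccccc2)c2ncn([C@@H]3O[C@H](CO)[C@@H](O)[C@H]3O)c2n1` gives 216000 nM
Compound 3 `CCCCSc1nc(NCc2ccccc2)c2ncn([C@@H]3O[C@H](CO)[C@@H](O)[C@H]3O)c2n1` gives 202000 nM

In a functional assay on a cell-free system (Platelet, plasma, Homo sapiens) for inhibition, with stated times of 1 min and 3 min (on this read-out higher numbers stand for weaker inhibition and lower numbers for stronger inhibition), compound 2 cannot be told apart from the other two compounds. Compound 4 `CCCCCCNc1nc(SCCC)nc2c1ncn2[C@@H]1O[C@H](CO)[C@@H](O)[C@H]1O` is not yet measured. It carries pentyl in place of phenyl on a saturated chain carbon bound to a nitrogen on an aromatic ring, so benzyl becomes hexyl: pentyl in place of phenyl on a saturated chain carbon bound to a nitrogen on an aromatic ring. Among the compounds with values here, the nearest precedent is a 1.4-fold higher number from compound 1 to compound 2 (0.16 log units; within the scatter), a swap of the group on that nitrogen, and it stayed within the scatter. A change elsewhere, on the chain at sulfur, gave a 1.1-fold lower number from compound 2 to compound 3 (0.03 log units; within the scatter), also within the scatter. Neither step points to a large shift, so a 1.3-fold lower number from compound 2 to compound 4 (0.10 log units; within the scatter) is expected, which means no step beyond the scatter in either direction. In this assay the estimated value for compound 4 is 170000 nM, with an expected range from 85000 nM to 340000 nM.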

Compound 4, half-maximal inhibitory concentration: 102000 nM
For compound 4 the middle estimate is 1.7-fold (0.22 log units) above the measured one, within the range that was stated.
By their numbers in this assay, from the lowest: compounds 4, 1, 3 and 2 (each within the scatter of the next, the first and the last beyond it).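

In this assay, within the data shown here, hexyl in place of benzyl on this nitrogen gives the first step beyond the scatter at this position (modest in size): a 2.1-fold lower number from compound 2 to compound 4 (0.33 log units; beyond the scatter). So losing the phenyl ring here does not weaken inhibition. Against cyclohexyl, however, the open hexyl chain cannot be told apart (a 1.5-fold lower number from compound 1 to compound 4 (0.17 log units; within the scatter)), so a ring on this nitrogen does not always give a higher number than a chain. No measurement here accounts for the step.

As far as these compounds go, whether a longer chain such as octyl, or a shorter one such as butyl, on this nitrogen would shift the number further stays open.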